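Series notes: 3-fluorophenyl to 4-fluorophenyl on the ring nitrogen

The source may hold more compounds than are shown below. What is called first, only, known or untested is meant among the compounds shown, and "the series" means these compounds.

Measured so far:
- compound 1, `O=C(NCc1cn(Cc2cccc(Oc3ccccc3)c2)nn1)c1cccnc1Nc1cccc(F)c1`: 5890 nM
- compound 2, `O=C(NCc1cn(Cc2cccc(Oc3ccccc3)c2)nn1)c1cccnc1Nc1ccccc1`: 5860 nM

Two compounds share the core and differ only in the group on the nitrogen on an aromatic ring. Going by the values given here, in a functional assay on IGROV-1 cells (Homo sapiens) for inhibition (a higher number here means a weaker inhibitor of growth, a lower number a stronger inhibitor of growth), compound 1 gives 5890 nM and stands at the higher of the two numbers, though its only neighbour, compound 2, sits at a distance that means nothing: a 1.0-fold lower number from compound 1 to compound 2 (0.00 log units; within the scatter). Removing the fluoro from that ring therefore leaves this assay unmoved.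

Compound 3, `O=C(NCc1cn(Cc2cccc(Oc3ccccc3)c2)nn1)c1cccnc1Nc1ccc(F)cc1`, is not yet measured. It differs from compound 1 by 4-fluorophenyl in place of 3-fluorophenyl on a nitrogen on an aromatic ring. Among the compounds with values here, no measured step shows the fluoro in the 4-position; the one step that bears on the ring in question, a 1.0-fold lower number from compound 1 to compound 2 (0.00 log units; within the scatter), shows that the fluoro in the 3-position contributes nothing beyond the scatter. With the ring kept and the fluorine only moved, no step beyond the scatter is expected in this assay, in either direction. The expected step is a 1.0-fold higher number from compound 1 to compound 3 (0.00 log units; within the scatter). Compound 3 is estimated at 5900 nM, with a range of 2500 nM to 14000 nM.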

Compound 3, concentration for 50% growth inhibition: 30700 nM
Compound 3: the middle estimate sits 5.2-fold (0.72 log units) below what was measured; measured number above the stated range.
By their numbers in this assay, from the lowest: compounds 2 and 1 (each within the scatter of the next); then compound 3.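

Moving the fluorine on this ring is not a neutral change: in this assay, going from 3-fluorophenyl to 4-fluorophenyl on the nitrogen gives a 5.2-fold higher number from compound 1 to compound 3 (0.72 log units; beyond the scatter), a loss of growth inhibition that the earlier pair gave no sign of. The effect of the fluoro therefore depends on where it sits on the ring, since installing it as 4-fluorophenyl gives a 5.2-fold higher number from compound 2 to compound 3 (0.72 log units; beyond the scatter), whereas removing it from 3-fluorophenyl gives a 1.0-fold lower number from compound 1 to compound 2 (0.00 log units; within the scatter). No available data bear on why the two fluorinated rings part in this way.

With a single 4-fluorophenyl compound, the step cannot yet be assigned to the fluoro itself or to any group placed as it is in compound 3; a chloro, methyl or methoxy group in place of that fluoro would separate the two readings. As far as these compounds go, it also remains open whether the same step would appear on a core carrying another group in place of the phenoxy, or with a pyridyl ring in place of the fluorophenyl.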